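This account rests on a few compounds, and the source may have more. Where it says the series, first, only, none or still open, it means among the compounds named here.

Measured compounds:
compound 1 `Cc1cc(Nc2cc(-c3ccccc3)[nH]n2)n2nc(SCCc3ccccc3)nc2n1`, 5620 nM
compound 2 `Cc1cc(Nc2ccn(Cc3ccccc3)n2)n2nc(SCc3ccc(Br)cc3)nc2n1`, 4720 nM
compound 3 `Cc1cc(Nc2cc(-c3ccccc3)[nH]n2)n2nc(SCc3cccc(Br)c3)nc2n1`, 4820 nM

In a functional assay on MGC-803 cells (Homo sapiens) for inhibition, read by MTT assay, with a stated time of 72 h (a lower number here means a stronger inhibitor, a higher number a weaker inhibitor), compound 1 gives 5620 nM, the highest of the three numbers, though its gaps to compound 3 and compound 2 both lie within the scatter. Compound 4 `Cc1cc(Nc2cc(-c3ccccc3)[nH]n2)n2ncnc2n1` has not been measured; it differs from compound 1 by hydrogen in place of phenethylsulfanyl on an aromatic carbon. Within the data shown here, no measured step covers removal of this group. Among the measured compounds shown here, the only step at the same place, a 1.2-fold lower number from compound 1 to compound 3 (0.07 log units; within the scatter), swapped one substituent on the sulfur for another and stayed within the scatter, which says nothing about losing the group outright. The expectation for compound 4 is therefore uncertain, with a 1.6-fold higher number from compound 1 to compound 4 (0.20 log units; within the scatter) as the estimated step. Compound 4 is estimated at 9000 nM, range 2500 nM to 30000 nM.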

Compound 4, half-maximal inhibitory concentration: 21700 nM
The estimate for compound 4 lay 2.4-fold (0.38 log units) below the measured number; the range from low to high includes it.
By their numbers in this assay, from the lowest: compounds 2, 3 and 1 (each within the scatter of the next); then compound 4.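

Taking the sulfanyl substituent off this aromatic carbon weakens inhibition in this assay on both comparisons available (a 3.9-fold higher number from compound 1 to compound 4 (0.59 log units; beyond the scatter)) and (a 4.5-fold higher number from compound 3 to compound 4 (0.65 log units; beyond the scatter)). The position therefore accepts phenethylsulfanyl or (3-bromobenzyl)sulfanyl without a difference beyond the scatter, while hydrogen gives a modest but real loss. Nothing measured here explains that loss.
Still open, from the compounds shown here alone, is whether the sulfur or the aromatic ring accounts for the difference. A methylsulfanyl group or an amine on this carbon would help separate the two.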